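This account rests on a few compounds, and the source may have more. Where it says the series, first, only, none or still open, it means among the compounds named here.

Measured so far in an ADME assay on RD cells (Homo sapiens) for cytotoxicity; on this read-out higher numbers stand for lower toxicity in this test and lower numbers for higher toxicity in this test:

Compound 1 `CNC(=S)N/N=C1\C(=O)Nc2ccccc21` gives in this assay a limit of the assay, > 25000 nM.
Compound 2 `CN1C(=O)/C(=N\NC(=S)Nc2ccccc2)c2ccccc21` gives in this assay a limit of the assay, > 25000 nM.
Compound 3 `O=C1Nc2ccccc2/C1=N/NC(=S)N1CCCCC1` gives in this assay a limit of the assay, > 25000 nM.

Compound 2 thus stands where every value of the series stands, at the limit of > 25000 nM in this assay, at which 3 of the 3 values shown sit. The change to compound 4 `O=C1Nc2ccccc2/C1=N/NC(=S)Nc1ccccc1` is hydrogen in place of methyl on an amide-type nitrogen in a ring. For the measured compounds named here, the one measured step, a step that the two limits leave unreadable from compound 1 to compound 3, concerns the thiocarbonyl substituent and is unreadable; no measured step touches the amide-type nitrogen in the ring. Nothing in the series therefore points to a readable step in this assay in either direction. Compound 4 is expected to remain at the limit, estimated at 40000 nM with a range of 15000 nM to 150000 nM. The expected step is a step that the limit leaves unreadable from compound 2 to compound 4.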

Compound 4, half-maximal cytotoxic concentration: > 25000 nM
Compound 4: no number, only a limit (the forecaster's own chance of this, stated with the estimate: 85%); the middle value lies beyond the limit too.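

For the compounds shown here, no step among compound 1, compound 2, compound 3 and compound 4 can be read in this assay, as all four values are limits: the limit of > 25000 nM in this assay, at which 4 of the 4 values shown sit.

Going by these compounds, whether the thiocarbonyl substituent or the amide-type nitrogen substituent affects cytotoxicity remains open.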